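The source may hold more compounds than are shown below. What is called first, only, known or untested is meant among the compounds shown, and "the series" means these compounds.

Series notes. Four compounds share one core and differ only in the group on a saturated chain carbon bound to a nitrogen on an aromatic ring. Compound 1 `N#Cc1ccc(Nc2nccc(N(CCCF)c3c(F)cc(-c4ccc(C#N)cc4)cc3F)n2)cc1` carries 2-fluoroethyl there, compound 2 `N#Cc1ccc(Nc2nccc(N(CCCCl)c3c(F)cc(-c4ccc(C#N)cc4)cc3F)n2)cc1` 2-chloroethyl, compound 3 `N#CCN(c1ccnc(Nc2ccc(C#N)cc2)n1)c1c(F)cc(-c2ccc(C#N)cc2)cc1F` cyano, and compound 4 `C=CCN(c1ccnc(Nc2ccc(C#N)cc2)n1)c1c(F)cc(-c2ccc(C#N)cc2)cc1F` vinyl.

In an ADME assay on MT4 cells (Homo sapiens) for cytotoxicity, read by MTT assay, with a stated time of 5 days (a lower number here means that less compound is tolerated, a higher number that more compound is tolerated), compound 1 gives 241000 nM. Compound 3 gives 206000 nM in this assay. In this assay compound 2 returns > 250000 nM, which is a limit of the assay and not a number (the limit of > 250000 nM in this assay, at which 1 of the 3 values shown sits). Compound 3 and compound 1 sit within the scatter of each other, a 1.2-fold lower number from compound 1 to compound 3 (0.07 log units; within the scatter), and the third value is a limit, so compound 3 has no separate standing among the numbers shown.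

The step to compound 4 is vinyl in place of cyano on a saturated chain carbon bound to a nitrogen on an aromatic ring. The measured steps at the same place are a 1.2-fold lower number from compound 1 to compound 3 (0.07 log units; within the scatter) and an at least 1.2-fold lower number from compound 2 to compound 3 (0.08 log units; that floor lies within the scatter), neither beyond the scatter; the halogen swap three bonds along the chain, an at least 1.0-fold higher number from compound 1 to compound 2 (0.01 log units; that floor lies within the scatter), was likewise flat. On that basis no step beyond the scatter is expected in this assay for compound 4, which means an expected 1.1-fold higher number from compound 3 to compound 4 (0.03 log units; within the scatter). Compound 4 is therefore estimated at 220000 nM in this assay, with a range from 120000 nM to 320000 nM, and a fair chance that only a limit is reported again.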

Compound 4, half-maximal cytotoxic concentration: 249000 nM
Compound 4: middle estimate off by 1.1-fold (0.05 log units), on the low side, within the range that was stated.
By their numbers in this assay, from the lowest: compounds 3, 1 and 4 (each within the scatter of the next). At a limit, above all of these: compound 2.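

In this assay, the change to vinyl removes the nitrile nitrogen and its hydrogen-bond acceptor from the place on a saturated chain carbon bound to a nitrogen on an aromatic ring, yet the step stays within the scatter: a 1.2-fold higher number from compound 3 to compound 4 (0.08 log units; within the scatter). The comparison with the fluorinated chain reads the same way, a 1.0-fold higher number from compound 1 to compound 4 (0.01 log units; within the scatter), so vinyl, cyano and 2-fluoroethyl cannot be separated at this position, and a group with a double bond now joins that flat set. The remaining step reads a number no higher from compound 2 to compound 4 (the limit leaves the size open). It cannot be read for size, because compound 2 stands at a limit of the assay and not at a number: the limit of > 250000 nM in this assay, at which 1 of the 4 values shown sits.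

As far as these compounds go, what an amine, a carboxylic acid or a longer chain at this place would give in this assay stays open. Also open is whether the flat reading belongs to this position or is set by the shared core, which is the same in all the compounds shown.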